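Fluoro Substitution on a Sulfone Analogue: An Expectation

A few compounds are considered here, and "the series" means these few. Any claim that something is new, unique, unknown or untested is made for them only; others in the source may bear on it.

Compound 1 `NS(=O)(=O)c1ccc(-c2oc3ccccc3c(=O)c2-c2ccc(F)cc2)cc1` and compound 2 `NS(=O)(=O)c1ccc(-c2oc3ccccc3c(=O)c2-c2ccccc2)cc1` share one core and differ by fluoro in place of hydrogen on an aromatic carbon. In an assay on isolated protein for inhibition of prostaglandin G/H synthase 1 (Mus musculus), tested at 10 ug/mL (on this read-out lower numbers stand for less inhibition and higher numbers for more inhibition at the one concentration tested (going by the name of the read-out)), compound 1 gives 67%, and compound 2 gives 61%; the step is a number 6 percentage points higher from compound 2 to compound 1 (within the scatter). Compound 3 `CS(=O)(=O)c1ccc(-c2oc3ccccc3c(=O)c2-c2ccccc2)cc1` differs from compound 2 by methyl in place of amino on a sulfonyl sulfur. In this assay compound 3 reaches only a limit, < 5%, which is the limit of < 5% in this assay, at which 1 of the 3 values shown sits. The step is a number at least 56 percentage points lower from compound 2 to compound 3 (beyond the scatter). Compound 4 `CS(=O)(=O)c1ccc(-c2oc3ccccc3c(=O)c2-c2cccc(F)c2)cc1` is not yet measured in this assay; it differs from compound 3 by fluoro in place of hydrogen on an aromatic carbon. This is the same kind of change as that between compound 2 and compound 1, though the place differs: para to a large group there, meta to a large group here. The earlier step of a number 6 percentage points higher from compound 2 to compound 1 (within the scatter) stayed within the scatter. Compound 4 is therefore expected to show a step that the limit leaves unreadable from compound 3 to compound 4. Compound 4 is estimated at 3%, most likely again only a limit.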

Compound 4, a percentage reported as inhibition, at one concentration (the size of the read-out at that concentration, not a potency): < 5%
Compound 4 gave a limit, no number; the forecaster's own chance of this, stated with the estimate: 75%; the middle value does not contradict the limit.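

Compound 3 and compound 4 both stand at a limit in this assay, so no step can be read between them: the limit of < 5% in this assay, at which 2 of the 4 values shown sit.

The compounds shown leave open whether fluoro in place of hydrogen changes inhibition at all when methyl stands on the sulfonyl sulfur.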